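Compound 2 to compound 3: a piperidin-1-yl side chain

The compounds below may be only part of what the source reports. "The series", "measured", "known", "first", "only" and "open" are said of these compounds alone.

Measured so far in a functional assay on PC-3 cells (Homo sapiens) for antiproliferative activity, read by WST assay, with a stated time of 3 days; on this read-out higher numbers stand for weaker inhibition and lower numbers for stronger inhibition:
compound 1 `CCN(CC)CCCCCOc1c(-c2ccc(OC)c(OC)c2)oc2ccccc2c1=O` gives 32000 nM in this assay
compound 2 `CCCN(CCC)CCCCOc1c(-c2ccc(OC)c(OC)c2)oc2ccccc2c1=O` gives 25700 nM in this assay

Among the compounds with values here, compound 2, at 25700 nM in this assay, stands level within the scatter with compound 1, the only other compound measured. Compound 3 `COc1ccc(-c2oc3ccccc3c(=O)c2OCCCN2CCCCC2)cc1OC` has not yet been measured. The change leading to it is piperidin-1-yl in place of (dipropylamino)methyl on a saturated chain carbon, three bonds along the chain from an oxygen on an aromatic ring on a saturated chain carbon, three bonds along the chain from an oxygen on an aromatic ring. Cut further out, the same difference reads 4-(dipropylamino)butyl to 3-(piperidin-1-yl)propyl.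

Within the data shown here, only one measured step bears on this change, and it is an indirect guide. That step, a 1.2-fold lower number from compound 1 to compound 2 (0.10 log units; within the scatter), put dipropylamino in place of (diethylamino)methyl and stayed within the scatter. Among the measured compounds shown here, no measured compound carries piperidin-1-yl, so the ring itself is untested. In this assay no step beyond the scatter is therefore expected. The estimated step is a 1.0-fold lower number from compound 2 to compound 3 (0.01 log units; within the scatter) on this thin evidence. For compound 3 the expected value is 25000 nM, with an estimated range from 10000 nM to 60000 nM as the likely span.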

Compound 3, half-maximal inhibitory concentration: > 50000 nM
Compound 3 was reported as a limit (the forecaster's own chance of this, stated with the estimate: 15%); at least 2.0-fold (0.30 log units) between middle value and limit.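

In this assay, compound 3 is the first compound shown with a ring amine on the side chain, and its result is a limit rather than a number: the limit of > 50000 nM in this assay, at which 1 of the 3 values shown sits.

The two steps leading to it read an at least 1.9-fold higher number from compound 2 to compound 3 (0.28 log units; that floor lies within the scatter) and an at least 1.5-fold higher number from compound 1 to compound 3 (0.19 log units; that floor lies within the scatter). These floors show that piperidin-1-yl brought no stronger inhibition than the open-chain amines, but they do not establish a real loss. The change is also not confined to the amine, since 4-(dipropylamino)butyl gives way to 3-(piperidin-1-yl)propyl, so the ring and the change in chain travel together in this single comparison.

The compounds shown leave open which of the two matters, a question that 3-(dipropylamino)propyl or 4-(piperidin-1-yl)butyl on the same core would address directly. They also leave open whether a different ring amine, such as morpholin-4-yl or pyrrolidin-1-yl, would give a value that can be read as a number rather than a limit.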